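Carboxy for nitro on a shared amide core

The compounds below may be only part of what the source reports. "The series", "measured", "known", "first", "only" and "open" are said of these compounds alone.

For the measured compounds named here, compound 2 `O=C(Nc1cc(-c2ccccc2)nn1-c1ccccc1)c1ccc([N+](=O)[O-])cc1` stands lowest of the two numbers so far in an assay on HEK293 cells for displacement of a labelled ligand from metabotropic glutamate receptor 5 (Rattus norvegicus) (a higher number here means a weaker inhibitor, a lower number a stronger inhibitor), at 250 nM; compound 1 `Cc1ccc(C(=O)Nc2cc(-c3ccccc3)nn2-c2ccccc2)cc1` gives 780 nM, and the one known step is a 3.1-fold lower number from compound 1 to compound 2 (0.49 log units; beyond the scatter). Compound 3 `O=C(O)c1ccc(C(=O)Nc2cc(-c3ccccc3)nn2-c2ccccc2)cc1` differs from compound 2 by carboxy in place of nitro on an aromatic carbon. Going by the values given here, no measured step swaps nitro for carboxy, so the known step gives only loose guidance. A change roughly the size of that step, toward a higher number, is expected for compound 3, namely a 4.8-fold higher number from compound 2 to compound 3 (0.68 log units; beyond the scatter). The estimate for compound 3 in this assay is 1200 nM, with a range from 250 nM to 6000 nM.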

Compound 3, inhibition constant: > 10000 nM
Compound 3 ended at the assay's limit; the forecaster's own chance of this, stated with the estimate: 15%; middle value at least 8.3-fold (0.92 log units) away from the limit.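

In this assay, the group at this place on the ring can do far more than shift the number modestly: carboxy for nitro gives an at least 40-fold higher number from compound 2 to compound 3 (1.60 log units; beyond the scatter), and carboxy for methyl gives an at least 12-fold higher number from compound 1 to compound 3 (1.10 log units; beyond the scatter). Nitro and carboxy have the same number of heavy atoms, yet only carboxy brings a hydrogen-bond donor, so heavy-atom count alone does not predict the outcome here. Compound 3 stands at a limit of the assay, not at a number, so both steps are minimum sizes: the limit of > 10000 nM in this assay, at which 1 of the 3 values shown sits.

As far as these compounds go, how far compound 3 lies beyond that limit stays open. Also open, from the compounds shown here alone, is how an amine or a methyl ester at this place would compare.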